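The source may hold more compounds than are shown below. What is called first, only, known or untested is meant among the compounds shown, and "the series" means these compounds.

Measured compounds in a functional assay on SW-620 cells (Homo sapiens) for cytotoxicity, read by MTT assay, with a stated time of 48 h; a higher number here means a weaker inhibitor, a lower number a stronger inhibitor:
compound 1 `CCCCCCCCCCCCCCNC(=O)[C@@H](N)[C@@H](C)O` gives 18700 nM
compound 2 `CCCCCCCCNC(=O)[C@@H](NC(=O)c1ccccc1)[C@@H](C)O` gives 200000 nM
compound 3 `CCCCCCCCCCCCNC(=O)[C@@H](NC(=O)c1ccccc1)[C@@H](C)O` gives 200000 nM

Compound 3 stands level with compound 2, the two together giving the highest numbers of the three; compound 1, the free amine with the longer chain, gives the lowest. Within the data shown here, the only single-point step, no change at the digits printed from compound 2 to compound 3 (within the scatter), shows that lengthening the alkyl amide chain within the benzoyl pair leaves the read-out where it was.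

Compound 4 `CCCCCCCCCCCCNC(=O)[C@@H](NC(=O)/C=C/c1ccccc1)[C@@H](C)O` keeps the chain and the core of compound 3 and changes the acyl group: 2-phenylethenyl in place of phenyl on a carbonyl carbon. Among the measured compounds shown here, no measured pair differs at the carbonyl carbon, so no step speaks to this change directly; the one step in hand, no change at the digits printed from compound 2 to compound 3 (within the scatter), concerns the chain end and is flat, offering no lever in either direction. With nothing to point to a shift, the expectation for this assay is a step of no size beyond the scatter, a 1.3-fold lower number from compound 3 to compound 4 (0.12 log units; within the scatter), carrying the same caution that compound 3 sits near the top of the range the assay reports. Compound 4 is therefore estimated at 150000 nM, with the range 50000 nM to 300000 nM.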

Compound 4, half-maximal inhibitory concentration: 200000 nM
Compound 4: the middle estimate sits 1.3-fold (0.12 log units) below what was measured, and the stated range covers the measured number.
By their numbers in this assay, from the lowest: compound 1; then compounds 2, 3 and 4 (each within the scatter of the next).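

In this assay, the first change read at the carbonyl carbon, 2-phenylethenyl in place of phenyl, gives no change at the digits printed from compound 3 to compound 4 (within the scatter), so the larger acyl group with its double bond outside the aromatic ring does not separate the pair. With no change at the digits printed from compound 2 to compound 3 (within the scatter), both single-place changes now read are flat, one at the chain and one on the carbonyl carbon, so neither position has yet produced a step beyond the scatter among the benzoyl and (2-phenylethenyl)carbonyl amides. No measurement on hand bears on why this acyl change leaves the read-out flat.

Compound 1 gives 18700 nM but differs from the other compounds in more than one place, so the compounds shown cannot separate the contribution of its free amine from that of its longer chain. Also open, from the compounds shown here alone, is whether a carboxylic acid or an amine carried on the aromatic ring of the acyl group, or a saturated 2-phenylethyl group on the carbonyl carbon, would move the number away from the level shared by compound 2, compound 3 and compound 4.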